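Amide-amine swap to a dihydroindole in the thiazole series

This account rests on a few compounds, and the source may have more. Where it says the series, first, only, none or still open, it means among the compounds named here.

Three compounds of the shared core have numbers in a functional assay for antagonist activity at thyroid hormone receptor alpha (Homo sapiens), read by fluorescence polarization; a lower number here means a stronger inhibitor, a higher number a weaker inhibitor. Compound 2 `CC1(C)CC2CC(C)(CN2C(=O)c2sc(-c3ccc(S(C)(=O)=O)c([N+](=O)[O-])c3)nc2C(F)(F)F)C1` gives 430 nM, the lowest of the three. Compound 3 `Cc1nc(-c2ccc(S(C)(=O)=O)c([N+](=O)[O-])c2)sc1C(=O)N1CC2(C)CC1CC(C)(C)C2` gives 3500 nM, and compound 1 `Cc1nc(-c2ccc(S(C)(=O)=O)c([N+](=O)[O-])c2)sc1C(=O)N1CCC(C)CC1` gives 5600 nM. Among the compounds with values here, the only single-point step measured is an 8.1-fold higher number from compound 2 to compound 3 (0.91 log units; beyond the scatter), methyl in place of trifluoromethyl on an aromatic carbon. Compound 1 and compound 3 share the methyl and differ only in the amine on the carbonyl carbon; their two values lie within about a two-step spread of each other, so the amine has so far shifted the number less than the trifluoromethyl has.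

Compound 4 `CC1Cc2ccccc2N1C(=O)c1sc(-c2ccc(S(C)(=O)=O)c([N+](=O)[O-])c2)nc1C(F)(F)F` keeps the trifluoromethyl of compound 2 and changes the amine: a group of 10 heavy atoms (9 carbon, 1 nitrogen; one five-membered non-aromatic ring with 1 hetero atom, one six-membered aromatic ring of carbon only) in place of a group of 11 heavy atoms (10 carbon, 1 nitrogen; one five-membered non-aromatic ring with 1 hetero atom, one six-membered non-aromatic ring of carbon only), on a carbonyl carbon. Within the data shown here, no measured step covers this change; the pair of compound 1 and compound 3 is the nearest guide and points to a modest move. Compound 4 is therefore expected to give 1000 nM, between 300 nM and 3500 nM, an expected step of a 2.3-fold higher number from compound 2 to compound 4 (0.37 log units; beyond the scatter).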

Compound 4, half-maximal inhibitory concentration: 1100 nM
Compound 4: middle estimate off by 1.1-fold (0.04 log units), on the low side; the measured number falls inside the stated range.
By their numbers in this assay, from the lowest: compound 2; then compound 4; then compounds 3 and 1 (each within the scatter of the next).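

With the trifluoromethyl held, the amine on the carbonyl carbon gives a step in this assay of a 2.6-fold higher number from compound 2 to compound 4 (0.41 log units; beyond the scatter); this is a measured, single-change effect of the amine, whereas compound 1 and compound 3, which carry the methyl, lie within the scatter of each other. The 2-methyl-2,3-dihydro-1H-indol-1-yl group, with its six-membered aromatic ring of carbon only, costs only a modest step at this position, so a non-aromatic six-membered ring in the amine is not required for activity in this pair. Nothing available here accounts for the size of this step.

Open, from the compounds shown here alone, is whether the step carries over with methyl in place of trifluoromethyl on the aromatic carbon, and what the methyl of the 2-methyl-2,3-dihydro-1H-indol-1-yl group contributes. Also open, going by these compounds, is what a morpholin-4-yl group or an amine bearing a carboxylic acid would give on the carbonyl carbon.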